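From 2,5-dichlorophenyl to 3,4-dichlorophenyl: an expectation for compound 4

This account rests on a few compounds, and the source may have more. Where it says the series, first, only, none or still open, it means among the compounds named here.

compound 1 `Cc1cc(S(N)(=O)=O)ccc1NC(=O)COc1ccc(Cl)cc1C(O)c1cccc([N+](=O)[O-])c1` gives 36900 nM
compound 2 `Cc1ccc(C(O)c2cc(Cl)ccc2OCC(=O)Nc2ccc(S(N)(=O)=O)cc2C)c(C)c1` gives 26400 nM
compound 3 `Cc1cc(S(N)(=O)=O)ccc1NC(=O)COc1ccc(Cl)cc1C(O)c1cc(Cl)ccc1Cl` gives 36200 nM

In an ADME assay on C8166 cells (Homo sapiens) for cytotoxicity, read by MTT assay (a lower number here means that less compound is tolerated, a higher number that more compound is tolerated), compound 3 stands at 36200 nM and lies within the scatter of compound 1 and compound 2. Compound 4 `Cc1cc(S(N)(=O)=O)ccc1NC(=O)COc1ccc(Cl)cc1C(O)c1ccc(Cl)c(Cl)c1` has the same atoms joined differently (3,4-dichlorophenyl in place of 2,5-dichlorophenyl on a saturated chain carbon bound to an aromatic carbon and an oxygen on a saturated carbon), with 3,4-dichlorophenyl in place of 2,5-dichlorophenyl on a saturated chain carbon bound to an aromatic carbon and an oxygen on a saturated carbon. Three measured steps changed the aromatic group at that place: a 1.4-fold lower number from compound 1 to compound 2 (0.15 log units; within the scatter) and a 1.0-fold lower number from compound 1 to compound 3 (0.01 log units; within the scatter) and a 1.4-fold higher number from compound 2 to compound 3 (0.14 log units; within the scatter) all stay within the scatter, so no step beyond the scatter is expected in this assay here. The expected change is a 1.1-fold lower number from compound 3 to compound 4 (0.04 log units; within the scatter) and lies within the scatter. Compound 4 is estimated at 33000 nM (expected range 18000 nM to 60000 nM).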

Compound 4, half-maximal cytotoxic concentration: 24000 nM
For compound 4 the middle estimate is 1.4-fold (0.14 log units) above the measured one, and the stated range covers the measured number.
By their numbers in this assay, from the lowest: compounds 4, 2, 3 and 1 (each within the scatter of the next).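

In this assay, moving the chlorines to give 3,4-dichlorophenyl produces a 1.5-fold lower number from compound 3 to compound 4 (0.18 log units; within the scatter), so the arrangement of the two chlorines on this ring does not separate the compounds. The comparisons with the other aromatic groups, a 1.1-fold lower number from compound 2 to compound 4 (0.04 log units; within the scatter) and a 1.5-fold lower number from compound 1 to compound 4 (0.19 log units; within the scatter), also stay within the scatter, so all four aromatic groups at this place remain indistinguishable. Nothing available explains these small differences. Still open, from the compounds shown here alone, is whether a non-aromatic group at this place, such as an amine or a carboxylic acid, would give a step beyond the scatter.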